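Bromine on the outer ring of compound 1

The source may report more compounds than this note shows. Statements on the series, on what has been measured and on what is new or still open speak of the compounds shown alone.

Compound 1 `O=S(=O)(Nc1cccc(CO)c1)c1ccc(-c2ccccc2)cc1`: 0.133 h
Compound 2 `O=S(=O)(Nc1ccc(CO)c(CO)c1)c1ccc(-c2ccc(F)cc2F)cc1`: 0.233 h
Compound 3 `O=S(=O)(Nc1ccc(-c2ccc(Cl)cc2Cl)cc1)c1cccc(CO)c1`: > 3.33 h (a limit)

In an ADME assay on microsomes from liver (Homo sapiens) for metabolic stability, read by LC-MS, tested at 3 uM (a lower number here means that the compound disappears faster, a higher number that the compound lasts longer), compound 1 gives 0.133 h. Compound 2 gives 0.233 h in this assay; the two numbers lie within the usual scatter of each other, so no difference between them can be claimed, and compound 1 simply sits among the shortest half-lives shown. For compound 3, this assay reports only a limit, > 3.33 h, not a number (the limit of > 3.33 h in this assay, at which 1 of the 3 values shown sits). Compound 3 also differs from compound 1 in more than one place, so the two cannot be compared step by step.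

Compound 4 `O=S(=O)(Nc1cccc(CO)c1)c1ccc(-c2ccc(Br)cc2)cc1` differs from compound 1 in one place: bromo in place of hydrogen on an aromatic carbon. Going by the values given here, no pair of measured compounds shows this kind of change, so the size of the step in this assay can only be guessed. For compound 4 a modest rise is expected, a 2.3-fold higher number from compound 1 to compound 4 (0.35 log units; beyond the scatter). The half-life of compound 4 is estimated at 0.3 h, with a range from 0.1 h to 1 h.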

Compound 4, half-life: 0.7 h
The estimate for compound 4 lay 2.3-fold (0.37 log units) below the measured number; measured number inside the range.
By their numbers in this assay, from the lowest: compounds 1 and 2 (each within the scatter of the next); then compound 4. At a limit, above all of these: compound 3.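

In this assay, the outer ring of compound 1 turns out to be a place where a single change can be read: going from phenyl to 4-bromophenyl gives a 5.3-fold higher number from compound 1 to compound 4 (0.72 log units; beyond the scatter), the first step shown between two measured compounds that differ in one place. The change adds only one heavy atom, a bromine on an aromatic carbon, para to a large group, yet the step lies beyond the usual scatter. No measurement shown gives a reason for this step.

This is one step at one position, so it cannot show whether bromine is special or whether other groups would do the same. A chloro group, a methoxy group, an amine or a carboxylic acid at this position would each test that question.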